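The compounds below may be only part of what the source reports. "The series", "measured", "known", "first", "only" and "open" are said of these compounds alone.

Three compounds have been examined in a functional assay with Alpha-1A adrenergic receptor (Homo sapiens) as the target, read by calcium flux (on this read-out higher numbers stand for larger maximal responses and lower numbers for smaller maximal responses), each carrying the same core with a different substituent on the aromatic nitrogen. Compound 1, `CCn1ccc(-c2ccccc2NCC2=NCCN2)n1`, gives a maximal response of 78%. Compound 2, `CCCCn1ncnc1-c1ccccc1NCC1=NCCN1`, reaches 86%, and compound 3, `CCCn1nccc1-c1ccccc1NCC1=NCCN1`, reaches 59%. Among these three numbers compound 1 stands just under compound 2, the two lying within the usual scatter of each other, so no order between them can be read; the gap from compound 1 down to compound 3 is beyond the scatter, so compound 3 gives the smaller maximal response of the two.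

The next compound, compound 4, `Cn1ccc(-c2ccccc2NCC2=NCCN2)n1`, differs from compound 1 in one place: hydrogen in place of methyl on a saturated chain carbon bound to an aromatic nitrogen. Within the data shown here, no pair of measured compounds shows the effect of such a change, so the step has to be judged from the structures alone. The change is small in what it removes, and the three measured compounds do not point to a direction for it; the step from compound 1 to compound 4 in this assay is expected to stay near zero, within the scatter, as a number 2 percentage points lower from compound 1 to compound 4 (within the scatter). Compound 4 is accordingly estimated to give a maximal response of 76%, with a range from 56% to 96%.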

Compound 4, largest response reached (reported as maximal response), in percent of the reference or control that the assay uses: 116%
The estimate for compound 4 lay 40 percentage points below the measured number, outside the stated range (above it).
By their numbers in this assay, from the lowest: compound 3; then compounds 1 and 2 (each within the scatter of the next); then compound 4.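

In this assay, among these compounds, the change from ethyl to methyl gives a number 38 percentage points higher from compound 1 to compound 4 (beyond the scatter) and so shows that this place on the shared core is not silent, which no earlier comparison could show, as no two of the earlier compounds differed in one place only. The step is large for what leaves, a methyl of 1 carbon, with no ring, no hydrogen-bond donor or acceptor and no net charge involved, so even the smallest trim of this chain can move the maximal response well beyond the scatter. The compounds shown hold no measurement that accounts for the size of this step.

From the compounds shown here alone, a single step gives two points on the core of compound 1, so it remains open whether the response follows chain length in any steady way or whether methyl is a special case. Going by these compounds, what an isopropyl group, a cyclopropyl ring or a 2-hydroxyethyl chain would do at the same place on that core also stays open, as does whether the same trim would give a step of like size on the cores of compound 2 or compound 3.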